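A few compounds are considered here, and "the series" means these few. Any claim that something is new, unique, unknown or untested is made for them only; others in the source may bear on it.

Within the data shown here, the three compounds measured so far share one core and differ in the aryl group carried on a five-membered ring. Compound 1 is `CCOC(=O)C1=Cc2ccccc2OC1(OCc1cc(-c2ccc(OC)cc2)no1)C(F)(F)F`. In a functional assay on DU-145 cells (Homo sapiens) for inhibition, read by MTT assay, with a stated time of 24 h (on this read-out higher numbers stand for weaker inhibition and lower numbers for stronger inhibition), compound 1 gives > 150000 nM, which is a limit of the assay rather than a number. Compound 2, `CCOC(=O)C1=Cc2ccccc2OC1(OCc1cn(-c2cccc(C(F)(F)F)c2)nn1)C(F)(F)F`, gives in this assay > 150000 nM, again a limit. Compound 3, `CCOC(=O)C1=Cc2ccccc2OC1(OCc1cn(-c2ccc([N+](=O)[O-])cc2)nn1)C(F)(F)F`, gives in this assay > 150000 nM, also a limit. Among the measured compounds shown here, the only single-point step among them, a step that the two limits leave unreadable from compound 2 to compound 3, runs between two limits and cannot be read; the one fact available is the limit of > 150000 nM in this assay, at which 3 of the 3 values shown sit. Compound 1 thus stands where every measured compound stands, at the limit, with no number that would set it apart from compound 2 or compound 3.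

Compound 4 is `CCOC(=O)C1=Cc2ccccc2OC1(OCc1cc(-c2ccc(F)cc2F)no1)C(F)(F)F`. It differs from compound 1 by 2,4-difluorophenyl in place of 4-methoxyphenyl on an aromatic carbon. For the measured compounds named here, no measured step bears directly on this change: the one step between measured compounds, a step that the two limits leave unreadable from compound 2 to compound 3, swaps the aryl group on an aromatic nitrogen and is unreadable. With nothing showing that an aryl swap of this kind moves the read-out off the limit, compound 4 is expected to give 200000 nM in this assay, with a range of 100000 nM to 400000 nM. The expected step, a step that the limit leaves unreadable from compound 1 to compound 4, is estimated to lie within the scatter.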

Compound 4, half-maximal inhibitory concentration: > 150000 nM
Compound 4 ended at the assay's limit; the forecaster's own chance of this, stated with the estimate: 85%; the middle value does not contradict the limit.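

Among these compounds, compound 1 and compound 4 both sit at a limit of the assay, so the step between them cannot be read and no new step comes from this result. One fact stands: the limit of > 150000 nM in this assay, at which 4 of the 4 values shown sit. The compounds shown leave open whether any change to the aryl group or the shared core would give a readable half-maximal inhibitory concentration.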